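This account rests on a few compounds, and the source may have more. Where it says the series, first, only, none or still open, it means among the compounds named here.

Measured so far in an assay on microsomes from liver for inhibition of sterol O-acyltransferase 1 (Rattus norvegicus); on this read-out higher numbers stand for weaker inhibition and lower numbers for stronger inhibition: compound 1 `CCCCCCCCCCCCn1nnc(C(NC(=O)c2c(C(C)C)cccc2C(C)C)c2ccccc2)n1` gives 810 nM; compound 2 `CCCCCCCCCCCCn1nnc(C(NC(=O)c2c(C)cccc2C)c2ccccc2)n1` gives 310 nM; compound 3 `CCCCCCCCCCCCn1nnc(C(NC(=O)c2ccc(OC)cc2)c2ccccc2)n1` gives 600 nM.

Compound 3 holds the second highest of the three numbers, but a 1.4-fold lower number from compound 1 to compound 3 (0.13 log units; within the scatter) and a 1.9-fold higher number from compound 2 to compound 3 (0.29 log units; within the scatter) both lie within the scatter, so compound 3 is not set apart from either neighbour. Compound 4 `CCCCCCCCCCCCn1nnc(C(NC(=O)c2ccc(C)cc2)c2ccccc2)n1` differs from compound 3 by methyl in place of methoxy on an aromatic carbon. Among the compounds with values here, no measured step exchanges methoxy for methyl; every measured step swaps the whole aryl group on the carbonyl carbon, and only a 2.6-fold lower number from compound 1 to compound 2 (0.42 log units; beyond the scatter) goes beyond the scatter, and that modestly. The change to compound 4 is smaller than any of those, so no step beyond the scatter is expected: a 1.2-fold lower number from compound 3 to compound 4 (0.08 log units; within the scatter). Compound 4 is estimated at 500 nM, range 250 nM to 1000 nM.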

Compound 4, half-maximal inhibitory concentration: 510 nM
Compound 4: the middle estimate sits 1.0-fold (0.01 log units) below what was measured, and the stated range covers the measured number.
By their numbers in this assay, from the lowest: compounds 2, 4, 3 and 1 (each within the scatter of the next, the first and the last beyond it).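

On the aromatic carbon para to a large group, methyl in place of methoxy gives a 1.2-fold lower number from compound 3 to compound 4 (0.07 log units; within the scatter) in this assay and does not separate the two compounds. With 4-methylphenyl on the carbonyl carbon, the series shows a 1.6-fold higher number from compound 2 to compound 4 (0.22 log units; within the scatter) and a 1.6-fold lower number from compound 1 to compound 4 (0.20 log units; within the scatter) in this assay, so neither 2,6-dimethylphenyl nor 2,6-diisopropylphenyl is set apart from it. Nothing available bears on the reason for these numbers.

From the compounds shown here alone, whether an amine or a carboxylic acid on this aromatic carbon would move the number beyond the scatter remains open.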